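The source may report more compounds than this note shows. Statements on the series, on what has been measured and on what is new or still open speak of the compounds shown alone.

Compound 1 `CC(C)c1ccc(-c2nc(SCc3cn(CC(=O)NC(=O)Nc4ccccn4)nn3)nc(Nc3cccc(Cl)c3)c2C#N)cc1` gives 18000 nM in a functional assay on MCF7 cells (Homo sapiens) for inhibition, read by MTT assay, with a stated time of 72 h; a lower number here means a stronger inhibitor, a higher number a weaker inhibitor.
Compound 2 `CC(C)c1ccc(-c2nc(SCc3cn(CC(=O)NC(=O)Nc4ccccn4)nn3)nc(Nc3ccccc3)c2C#N)cc1` gives only a limit of the assay, > 64000 nM, in this assay.
Compound 3 `Cc1cccc(Nc2nc(SCc3cn(CC(=O)NC(=O)Nc4ccccn4)nn3)nc(-c3ccc(C(C)C)cc3)c2C#N)c1` likewise gives only a limit of the assay, > 64000 nM, in this assay.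

Compound 2 thus stands at the upper limit of this assay, a position it shares with compound 3 (the limit of > 64000 nM in this assay, at which 2 of the 3 values shown sit). The step of an at least 3.5-fold higher number from compound 1 to compound 2 (0.55 log units; beyond the scatter) and the step of an at least 3.5-fold higher number from compound 1 to compound 3 (0.55 log units; beyond the scatter) both run toward that limit, while the step that the two limits leave unreadable from compound 2 to compound 3 cannot be read.

Compound 4 `CC(C)c1ccc(-c2nc(SCc3cn(CC(=O)NC(=O)Nc4ccccn4)nn3)nc(Nc3ccccc3O)c2C#N)cc1` differs from compound 2 by hydroxy in place of hydrogen on an aromatic carbon. Within the data shown here, no measured step introduces a hydroxy, so the only guidance is that both changes at this position in the shared core, from compound 1 to compound 2 and from compound 1 to compound 3, gave weaker inhibitors sitting at the limit. Compound 4 is therefore expected to remain a weak inhibitor, with the step of an at least 1.1-fold lower number from compound 2 to compound 4 (0.06 log units; that floor lies within the scatter) estimated to stay within the scatter and a fair chance of another limit. Compound 4 is estimated at 55000 nM, in the range 15000 nM to 150000 nM.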

Compound 4, half-maximal inhibitory concentration: > 64000 nM
Compound 4: no number, only a limit (the forecaster's own chance of this, stated with the estimate: 60%); at least 1.1-fold (0.06 log units) between middle value and limit.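

Among the groups shown on this nitrogen, a hydroxy ortho to a large group is the first that adds a hydrogen-bond donor and acceptor, yet it does not bring a readable number in this assay. Among these compounds, compound 4 gives only a limit of the assay, and only the 3-chlorophenyl group of compound 1 has so far given a number: the limit of > 64000 nM in this assay, at which 3 of the 4 values shown sit. The one readable step is an at least 3.5-fold higher number from compound 1 to compound 4 (0.55 log units; beyond the scatter), so the 2-hydroxyphenyl group goes with the phenyl and 3-methylphenyl groups, and the steps among compound 2, compound 3 and compound 4 cannot be read.

As far as these compounds go, it remains open whether a bromo or a trifluoromethyl in place of the chloro of compound 1 would also give a number. From the compounds shown here alone, whether a methoxy or an amine in place of the hydroxy of compound 4 would do so is also open.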